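Swapping the piperidine for a hydantoin: solubility expectation

The source may report more compounds than this note shows. Statements on the series, on what has been measured and on what is new or still open speak of the compounds shown alone.

Measured compounds:
- compound 1 `CN1CCN(C[C@H]2CN(c3ccc(-n4cc(-c5ccccn5)cn4)c(F)c3)C(=O)O2)CC1`: 1690000 nM
- compound 2 `O=C1O[C@@H](CN2CCCCC2)CN1c1ccc(-n2cc(-c3ccccn3)cn2)c(F)c1`: 219000 nM
- compound 3 `O=C1O[C@@H](CN2CCC(c3ccc(F)cc3)CC2)CN1c1ccc(-n2cc(-c3ccccn3)cn2)c(F)c1`: <= 19400 nM

In a physicochemical assay for solubility, read by HPLC, with a stated time of 24 h (on this read-out higher numbers stand for higher solubility and lower numbers for lower solubility), compound 1 gives 1690000 nM. Compound 2 gives 219000 nM, the lower of the two real numbers, with compound 1 standing a 7.7-fold lower number from compound 1 to compound 2 (0.89 log units; beyond the scatter). For compound 3 this assay reports only a limit, <= 19400 nM, which is the limit of <= 19400 nM in this assay, at which 1 of the 3 values shown sits.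

Compound 4 `O=C1CNC(=O)N1C[C@H]1CN(c2ccc(-n3cc(-c4ccccn4)cn3)c(F)c2)C(=O)O1` keeps the shared core of compound 2 and changes only the group on the side chain: 2,5-dioxoimidazolidin-1-yl in place of piperidin-1-yl on a saturated chain carbon bound to a saturated ring carbon. For the measured compounds named here, two measured steps touch that same place. Going from compound 1 to compound 2 gave a 7.7-fold lower number from compound 1 to compound 2 (0.89 log units; beyond the scatter), and going from compound 2 to compound 3 gave an at least 11-fold lower number from compound 2 to compound 3 (1.05 log units; beyond the scatter); both changes at this position lowered solubility well beyond the scatter, while no change here has raised it.

The 2,5-dioxoimidazolidin-1-yl group is neither the basic ring of compound 2 nor the aryl-substituted ring of compound 3, so neither step maps onto it directly. Going by the values given here, still, the only evidence at this position points downward, so a fall is expected, estimated as a 6.3-fold lower number from compound 2 to compound 4 (0.80 log units; beyond the scatter). Compound 4 is therefore expected to give about 35000 nM, within a range from 6000 nM to 200000 nM, with a real chance that this assay again reports only a limit.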

Compound 4, solubility: 1630000 nM
The estimate for compound 4 lay 47-fold (1.67 log units) below the measured number; measured number above the stated range.
By their numbers in this assay, from the lowest: compound 2; then compounds 4 and 1 (each within the scatter of the next). At a limit, below all of these: compound 3.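

In this assay, this position now shows an upward step, the only one among the steps shown here: 2,5-dioxoimidazolidin-1-yl in place of piperidin-1-yl gives (a 7.4-fold higher number from compound 2 to compound 4 (0.87 log units; beyond the scatter)). Putting the same ring in place of 4-methylpiperazin-1-yl gives (a 1.0-fold lower number from compound 1 to compound 4 (0.02 log units; within the scatter)), so two clearly different groups on this saturated chain carbon read alike, and the earlier run of downward steps does not hold for every change here. Piperidin-1-yl and 2,5-dioxoimidazolidin-1-yl are both counted as having no net charge, so that count does not separate them, although the entering ring has a hydrogen-bond donor and two double bonds outside aromatic rings, and the leaving ring has neither.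

A carboxylic acid, a morpholin-4-yl group or an open-chain urea on the same saturated chain carbon would help show whether other groups reach similar numbers. Which feature of the 2,5-dioxoimidazolidin-1-yl ring goes with the higher number stays open, and nothing measured in the compounds shown accounts for the rise.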